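The source may hold more compounds than are shown below. What is called first, only, known or untested is meant among the compounds shown, and "the series" means these compounds.

Measured compounds in the series:

Compound 1, `CCCCCCSc1n[nH]c(-n2[se]c3ccccc3c2=O)n1`: 20300 nM
Compound 2, `CC(C)Sc1n[nH]c(-n2[se]c3ccccc3c2=O)n1`: 36600 nM
Compound 3, `O=c1c2ccccc2[se]n1-c1nc(SCc2ccc([N+](=O)[O-])cc2)n[nH]1`: 9140 nM

In a functional assay on A549 cells (Homo sapiens) for antiproliferative activity, read by CCK-8 assay, with a stated time of 48 h (a lower number here means a stronger inhibitor, a higher number a weaker inhibitor), compound 2 gives the highest of the three numbers; its nearest neighbour is compound 1, a step within the scatter, while compound 3 sits beyond the scatter on the lower side. Compound 4, `CCSc1n[nH]c(-n2[se]c3ccccc3c2=O)n1`, has not yet been measured. It differs from compound 2 in one place: hydrogen in place of methyl on a saturated chain carbon bound to a saturated chain carbon and a sulfur.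

Going by the values given here, the only measured step that bears on this change is the one on the same sulfur, a 1.8-fold higher number from compound 1 to compound 2 (0.26 log units; within the scatter), where a large change of the alkyl chain left the number within the scatter. Shortening isopropyl to ethyl is a smaller change of the same kind, so no step beyond the scatter is expected here, in either direction. The expected step, a 1.1-fold lower number from compound 2 to compound 4 (0.06 log units; within the scatter), is therefore essentially flat. For compound 4 the number in this assay is estimated at 32000 nM, with a range from 12000 nM to 85000 nM.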

Compound 4, half-maximal inhibitory concentration: 39600 nM
For compound 4 the middle estimate is 1.2-fold (0.09 log units) below the measured one, within the range that was stated.
By their numbers in this assay, from the lowest: compound 3; then compounds 1, 2 and 4 (each within the scatter of the next).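

In this assay, isopropyl to ethyl on the sulfur leaves the number in place (a 1.1-fold higher number from compound 2 to compound 4 (0.03 log units; within the scatter)), so trimming a single methyl from the branch does not register at this position. The two unbranched chains, hexyl and ethyl, also stay within the scatter of each other (a 2.0-fold higher number from compound 1 to compound 4 (0.29 log units; within the scatter)), which adds that across compounds 1, 2 and 4 neither branching nor chain length, from ethyl to hexyl, has yet produced a step beyond the scatter. Nothing available gives a reason for this flat behaviour.

As far as these compounds go, whether a chain longer than hexyl would give a step beyond the scatter remains open. So does the effect of an amine or a carboxylic acid on the chain carried by the sulfur.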